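The source may report more compounds than this note shows. Statements on the series, on what has been measured and on what is new or still open speak of the compounds shown alone.

Measured compounds:
compound 1, `CCN1CCc2c(sc(NC(=O)Nc3ccc(Cl)cc3)c2C(N)=O)C1`, 3120 nM
compound 2, `CCN1CCc2c(sc(NC(=O)Nc3ccc(I)cc3)c2C(N)=O)C1`, 1620 nM

In a functional assay (strain AB) with Danio rerio as the target, read by microscopy, with a stated time of 1 h (a higher number here means that more compound is needed for the effect, a lower number that less compound is needed), compound 1 gives 3120 nM, the highest of the two numbers in hand; the nearest is compound 2 at 1620 nM, and the step of a 1.9-fold lower number from compound 1 to compound 2 (0.28 log units; within the scatter) lies within the scatter, so no order between the two can be read from these values. Among the measured compounds shown here, that single step, iodo in place of chloro on an aromatic carbon, is the only measured change in this set.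

Compound 3, `CC(C)(C)OC(=O)CCCN1CCc2c(sc(NC(=O)Nc3ccc(Cl)cc3)c2C(N)=O)C1`, has not yet been measured in this assay. It differs from compound 1 as follows: (tert-butoxycarbonyl)methyl in place of hydrogen on a saturated chain carbon, two bonds along the chain from an amine nitrogen in a ring. For the measured compounds named here, this change sits on the saturated chain at the ring amine, a region that none of the measured steps touches. The step from compound 1 to compound 2 concerns a halogen on an aromatic carbon and does not bear on this change. Going by the values given here, with no measured step to go by, the expectation for compound 3 in this assay is a number close to that of compound 1, with a wide range on either side. The step of a 1.0-fold lower number from compound 1 to compound 3 (0.02 log units; within the scatter) is thus expected to be small, and compound 3 is estimated at 3000 nM, within 900 nM to 10000 nM.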

Compound 3, half-maximal effective concentration: 560 nM
The estimate for compound 3 lay 5.4-fold (0.73 log units) above the measured number; measured number below the stated range.
By their numbers in this assay, from the lowest: compound 3; then compounds 2 and 1 (each within the scatter of the next).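

The saturated chain at the ring amine proves to be a place where a change registers in this assay: (tert-butoxycarbonyl)methyl in place of hydrogen on a saturated chain carbon, two bonds along the chain from an amine nitrogen in a ring, gives a 5.6-fold lower number from compound 1 to compound 3 (0.75 log units; beyond the scatter). Among the compounds shown here, this modest step lies beyond the scatter, whereas the only earlier step, a 1.9-fold lower number from compound 1 to compound 2 (0.28 log units; within the scatter), concerned a halogen on an aromatic carbon and stayed within it. The position therefore carries a group of 8 heavy atoms, read cut one bond further out as ethyl to 3-(tert-butoxycarbonyl)propyl, with less compound needed for the effect, although nothing at hand gives a reason for this step.

The compounds shown leave open whether the lower number goes with the tert-butoxycarbonyl group itself or with the longer chain alone, a question that a plain butyl chain, a 3-carboxypropyl group or a chain bearing an amine in the same place would address. Also open, as far as these compounds go, is whether the step holds with iodo in place of chloro on an aromatic carbon.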